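The compounds below may be only part of what the source reports. "The series", "measured", "known", "first", "only" and "open" are said of these compounds alone.

Of the compounds shown here, two have so far been tested in an ADME assay on L02 cells (Homo sapiens) for antiproliferative activity, read by MTT assay, with a stated time of 48 h; a lower number here means a stronger inhibitor, a higher number a weaker inhibitor. Compound 1 `N#CC1=C(N)Oc2c(c3nc4ccccc4nc3c3ccccc23)C12C(=O)N(Cc1cnnn1-c1ccc([N+](=O)[O-])cc1)c1ccccc12` returned only a limit of the assay, not a number: in this assay compound 1 gives > 50000 nM. Compound 2 `N#CC1=C(N)Oc2c(N)cc3nc4ccccc4nc3c2C12C(=O)N(Cc1cnnn1-c1ccc(F)cc1)c1ccccc12` also returned only a limit: in this assay compound 2 gives > 50000 nM. Where compound 2 stands is therefore a boundary rather than a measured point, and the two values shown sit at the same place, as the limit of > 50000 nM in this assay, at which 2 of the 2 values shown sit, records. Compound 3 `N#CC1=C(N)Oc2c(N)cc3nc4ccccc4nc3c2C12C(=O)N(Cc1cnnn1-c1cc(Cl)ccc1Cl)c1ccccc12` has not been measured. It differs from compound 2 in one place: 2,5-dichlorophenyl in place of 4-fluorophenyl on an aromatic nitrogen. Among the compounds with values here, no step between measured compounds is available, so nothing measured says how this change moves the read-out, and the expectation can rest only on where compound 2 sits. The step from compound 2 to compound 3 is expected to be none beyond the scatter, meaning a number no higher from compound 2 to compound 3 (the limit leaves the size open). In this assay compound 3 is expected to give about 50000 nM, within a range from 20000 nM to 150000 nM, and the assay will most probably again report only a limit.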

Compound 3, half-maximal inhibitory concentration: > 50000 nM
Compound 3: no number, only a limit; the forecaster's own chance of this, stated with the estimate: 75%; the middle value lies on the limit itself.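

Compound 3, like compound 2, returned only a limit in this assay, so no step can be read between compound 2 and compound 3 for 2,5-dichlorophenyl in place of 4-fluorophenyl. The compounds shown leave open how they rank and which change, if any, would yield a measured number, because all share one boundary: the limit of > 50000 nM in this assay, at which 3 of the 3 values shown sit.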